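A few compounds are considered here, and "the series" means these few. Any claim that something is new, unique, unknown or untested is made for them only; others in the source may bear on it.

Measured in a functional assay on NZB5 cells (Homo sapiens) for inhibition, read by thymidine incorporation, with a stated time of 5 days; a higher number here means a weaker inhibitor, a lower number a stronger inhibitor:
- Compound 1 `Cc1ccc(C)c(S(=O)(=O)N(C)/N=C/c2cnn3ccc(C#N)cc23)c1`: 2100 nM
- Compound 2 `Cc1ccc(Br)cc1S(=O)(=O)N(C)/N=C/c1cnn2ccc(C#N)cc12`: 700 nM
- Compound 3 `CC(C)c1ccc([N+](=O)[O-])cc1S(=O)(=O)N(C)/N=C/c1cnn2ccc(C#N)cc12`: 180 nM

Compound 2, at 700 nM, holds the second highest of these three numbers, so it sits in the middle of the set. Compound 4 `CC(=O)Nc1ccc(C)c(S(=O)(=O)N(C)/N=C/c2cnn3ccc(C#N)cc23)c1` keeps the core of compound 2 but carries acetamido in place of bromo on an aromatic carbon.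

Going by the values given here, only one measured step bears directly on this change. It is a 3.0-fold lower number from compound 1 to compound 2 (0.48 log units; beyond the scatter), a modest change beyond the scatter, seen with bromo in place of methyl on an aromatic carbon. Among the compounds with values here, it shows that the group on this carbon can shift the number, but no measured compound carries acetamido there. Within the data shown here, compound 3 differs from compound 2 in more than one place, so it gives no clean step, though compound 3 with its value of 180 nM argues for a wide range.

Losing the bromo of compound 2 is expected to give back a modest step, so the expectation is a 2.1-fold higher number from compound 2 to compound 4 (0.33 log units; beyond the scatter) in this assay. For compound 4 the estimated value is 1500 nM, with an expected range of 400 nM to 5000 nM.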

Compound 4, half-maximal inhibitory concentration: > 20000 nM
Compound 4 ended at the assay's limit (the forecaster's own chance of this, stated with the estimate: 8%); at least 13-fold (1.12 log units) between middle value and limit.
By their numbers in this assay, from the lowest: compound 3; then compound 2; then compound 1. At a limit, above all of these: compound 4.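

In this assay compound 4 stands at a limit, not at a number: the limit of > 20000 nM in this assay, at which 1 of the 4 values shown sits.

Even so, acetamido on this carbon, para to a methyl group, gives an at least 28-fold higher number from compound 2 to compound 4 (1.45 log units; beyond the scatter), and measured against methyl it gives an at least 9.5-fold higher number from compound 1 to compound 4 (0.97 log units; beyond the scatter). The earlier compounds had shown only a modest shift at this carbon, a 3.0-fold lower number from compound 1 to compound 2 (0.48 log units; beyond the scatter), so the group here can move the number much further, and towards a weaker inhibitor, than the swap between methyl and bromo revealed.

The compounds shown leave open which part of acetamido matters: the amide hydrogen, the carbonyl or simply the larger group of atoms. An amine, a methoxy group or a longer chain on this same carbon would help to separate these possibilities.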